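The source may report more compounds than this note shows. Statements on the series, on what has been measured and on what is new or still open speak of the compounds shown alone.

Compound 3 `CC(C)Cn1c(=O)n(C)c(=O)c2nc(C(=O)N(C)CCCO)c(Cc3cccc4ccccc34)nc21` sits at a limit in a functional assay on Raji cells (Homo sapiens) for inhibition, read by MTT assay, with a stated time of 96 h; on this read-out lower numbers stand for an effect already at smaller amounts and higher numbers for an effect only at larger amounts of compound: its value there, > 10000 nM, is not a number but the edge of what the measurement covers. Compound 2 `CC(C)Cn1c(=O)n(C)c(=O)c2nc(C(=O)NCCCO)c(Cc3cccc4ccccc34)nc21` sits at the same kind of limit, giving > 10000 nM. Among the compounds with values here, the only measured step, a step that the two limits leave unreadable from compound 2 to compound 3, is therefore unreadable, as the limit of > 10000 nM in this assay, at which 2 of the 3 values shown sit, records. Compound 1 `CC(C)Cn1c(=O)n(C)c(=O)c2c1nc(Cc1cccc3ccccc13)c(=O)n2CCCCO`, built differently around the shared core, gives 150 nM in this assay . Compound 4 `CC(C)Cn1c(=O)n(C)c(=O)c2nc(-c3c(CCCO)nnn3C)c(Cc3cccc4ccccc34)nc21` differs from compound 3 by 4-(3-hydroxypropyl)-1-methyl-1H-1,2,3-triazol-5-yl in place of (3-hydroxypropyl)(methyl)carbamoyl on an aromatic carbon. No measured step bears on this exchange, so its size and direction cannot be read from the numbers shown. Compound 4 is expected to give 6000 nM, between 1000 nM and 30000 nM. This estimate means a step of an at least 1.6-fold lower number from compound 3 to compound 4 (0.22 log units; that floor lies within the scatter) and is expected to stay close to the limit.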

Compound 4, half-maximal effective concentration: > 10000 nM
Compound 4: a limit, no number; the forecaster's own chance of this, stated with the estimate: 55%; middle value at least 1.6-fold (0.22 log units) away from the limit.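

Compound 4 also sits at a limit, so no step linking it to compound 2 or compound 3 can be read: the limit of > 10000 nM in this assay, at which 3 of the 4 values shown sit.

From the compounds shown here alone, whether 4-(3-hydroxypropyl)-1-methyl-1H-1,2,3-triazol-5-yl or (3-hydroxypropyl)(methyl)carbamoyl gives the lower number remains open.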